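Swapping the aryl group on the ring nitrogen

A few compounds are considered here, and "the series" means these few. Any claim that something is new, unique, unknown or untested is made for them only; others in the source may bear on it.

Measured so far:
compound 1 `N#Cc1ccc(N2CCN(C(=S)SCc3ccc(C(=O)Nc4ccccc4N)cc3)CC2)cc1` gives 34.5%
compound 2 `CC1CCN(C(=S)SCc2ccc(C(=O)Nc3ccccc3N)cc2)CC1` gives 28.1%

Going by the values given here, in a functional assay on MGC-803 cells (Homo sapiens) for antiproliferative activity, read by CCK-8 assay, with a stated time of 72 h, tested at 2 uM (a lower number here means a weaker effect, a higher number a stronger effect of the compound at the concentration tested), compound 1 gives 34.5%, the higher of the two numbers known, while compound 2 gives 28.1%; the gap between them is within the scatter of this kind of measurement, so the two cannot be ranked. Compound 3 `Nc1ccccc1NC(=O)c1ccc(CSC(=S)N2CCN(c3ccncc3)CC2)cc1` has not yet been measured. It differs from compound 1 in a single place: pyridin-4-yl in place of 4-cyanophenyl on an amine nitrogen in a ring. Among the compounds with values here, no measured pair shows a step of this kind, so the expectation rests on the two numbers alone. Since both measured compounds sit in the same region, the step in this assay is expected to be small, if anything slightly downward, and likely within the scatter, so that compound 3 is expected to show a change of a number 4.5 percentage points lower from compound 1 to compound 3 (within the scatter). Compound 3 is therefore estimated at 30%, with a range from 15% to 45%.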

Compound 3, a percentage reported as inhibition, at one concentration (the size of the read-out at that concentration, not a potency): 64.8%
The estimate for compound 3 lay 34.8 percentage points below the measured number; the measured number lies above the stated range.
By their numbers in this assay, from the lowest: compounds 2 and 1 (each within the scatter of the next); then compound 3.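

In this assay, placing pyridin-4-yl in place of 4-cyanophenyl on an amine nitrogen in a ring gives a number 30.3 percentage points higher from compound 1 to compound 3 (beyond the scatter). Compounds 1 and 2 differ in more than one place, so they could not show what this pair shows: a change at this one position alone can move the read-out well beyond the usual scatter. Nothing at hand explains why this step is so large.

As far as these compounds go, the pair changes two things at once, trading a ring of carbon only for one with a hetero atom and losing the nitrile, so the part each plays stays open. Plain phenyl, pyridin-3-yl and pyridin-2-yl on the same nitrogen would help separate these, and would show whether the place of the ring nitrogen matters.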